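Nitro in place of bromo: the step to compound 4

The source may report more compounds than this note shows. Statements on the series, on what has been measured and on what is new or still open speak of the compounds shown alone.

Compound 1 `Cc1nc(-c2cccnc2)sc1-c1nnc(Cc2ccccc2)o1` — in an ADME assay on HeLa cells (Homo sapiens) for cytotoxicity, read by MTT assay (a higher number here means that more compound is tolerated, a lower number that less compound is tolerated), compound 1 sits at the limit of the assay, > 100 ug/mL.
Compound 2 `Cc1nc(-c2cccnc2)sc1-c1nnc(-c2ccc(Br)cc2)o1` — in this assay compound 2 sits at the limit of the assay, > 100 ug/mL.
Compound 3 `Cc1nc(-c2cccnc2)sc1-c1nnc(-c2ccccc2Cl)o1` — in this assay compound 3 sits at the limit of the assay, > 100 ug/mL.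

Compound 2 therefore stands where all three measured compounds stand: the limit of > 100 ug/mL in this assay, at which 3 of the 3 values shown sit. The change to compound 4 `Cc1nc(-c2cccnc2)sc1-c1nnc(-c2ccc([N+](=O)[O-])cc2)o1` is nitro in place of bromo on an aromatic carbon. The steps that touch this position, a step that the two limits leave unreadable from compound 1 to compound 2 and a step that the two limits leave unreadable from compound 2 to compound 3, give no readable size. The expectation for this assay is a step that the limit leaves unreadable from compound 2 to compound 4 that stays within the scatter. Compound 4 is therefore estimated at 110 ug/mL, between 50 ug/mL and 250 ug/mL.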

Compound 4, half-maximal cytotoxic concentration: > 100 ug/mL
Compound 4 was reported as a limit; the forecaster's own chance of this, stated with the estimate: 75%; the middle value lies beyond the limit too.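

Compound 4, like compound 2, stands at a limit in this assay, so no new step can be read between these two compounds: the limit of > 100 ug/mL in this assay, at which 4 of the 4 values shown sit.

The compounds shown leave open at what concentration any of them becomes cytotoxic, and whether nitro and bromo differ at all.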